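Aldehyde dehydrogenase 1A1 series: sulfur-linked benzylic side chains

A few compounds are considered here, and "the series" means these few. Any claim that something is new, unique, unknown or untested is made for them only; others in the source may bear on it.

Measured so far:
compound 1, `Cn1ncc2c(=O)n(-c3ccccc3)c(SC(C)(C)c3ccccc3)nc21`, 1900 nM
compound 2, `Cn1ncc2c(=O)n(-c3ccccc3)c(SCc3cccc(F)c3)cc21`, 240 nM
compound 3, `CC(Sc1nc2c(cnn2C)c(=O)n1-c1ccccc1)c1cccc(F)c1`, 151 nM

In an assay on isolated protein for inhibition of aldehyde dehydrogenase 1A1 (Homo sapiens) (on this read-out lower numbers stand for stronger inhibition and higher numbers for weaker inhibition), compound 3 gives the lowest of the three numbers. Its nearest neighbour is compound 2, whose value in this assay is within the scatter of that of compound 3, so no order between these two is claimed. Going by the values given here, compound 1 stands furthest away; the step of a 13-fold lower number from compound 1 to compound 3 (1.10 log units; beyond the scatter) is the only single-place step among the measured compounds and it is large.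

Compound 4, `CC(Sc1nc2c(cnn2C)c(=O)n1-c1ccccc1)c1cncnc1`, is not yet measured. Relative to compound 3 the change is pyrimidin-5-yl in place of 3-fluorophenyl on a saturated chain carbon bound to a saturated chain carbon and a sulfur. Among the compounds with values here, no measured pair shows a ring exchange of this kind on the side chain; the one step on record, from compound 1 to compound 3, concerns the chain carbon itself and the fluorine-bearing ring is kept. It therefore gives no direct guide to the size of the present step. With nothing beyond the scatter to point either way, the expectation for compound 4 in this assay is a number near that of compound 3, the step of a 2.1-fold higher number from compound 3 to compound 4 (0.33 log units; beyond the scatter) being estimated as small. Compound 4 is expected at 320 nM, with a range from 120 nM to 900 nM.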

Compound 4, half-maximal inhibitory concentration: 94 nM
Compound 4: the middle estimate sits 3.4-fold (0.53 log units) above what was measured, outside the stated range (below it).
By their numbers in this assay, from the lowest: compounds 4, 3 and 2 (each within the scatter of the next, the first and the last beyond it); then compound 1.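

In this assay the exchange of 3-fluorophenyl for pyrimidin-5-yl on a saturated chain carbon bound to a saturated chain carbon and a sulfur gives a 1.6-fold lower number from compound 3 to compound 4 (0.21 log units; within the scatter) and so leaves no readable difference between the two rings. This position therefore tolerates a six-membered aromatic ring with 2 hetero atoms and 2 hydrogen-bond acceptors as well as the carbon-only, fluorine-bearing ring, so the fluorine is not needed to keep a value of this order in compound 4. The wider comparison, a 20-fold lower number from compound 1 to compound 4 (1.31 log units; beyond the scatter) for 1-(pyrimidin-5-yl)ethyl in place of 1-methyl-1-phenylethyl on a sulfur, stays large, but it changes chain carbon and ring together, and no measurement on hand explains why the two rings read alike.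

Open, from the compounds shown here alone, is whether a pyridin-3-yl ring or an unsubstituted phenyl ring on the same chain carbon would also fall within the scatter of these two compounds. Also open, going by these compounds, is how far this position extends to larger or charged groups, such as an amine or a carboxylic acid on the pyrimidin-5-yl ring.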